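The compounds below may be only part of what the source reports. "The series", "measured", "known", "first", "only" and "open" are said of these compounds alone.

Among the measured compounds shown here, in a functional assay on CWR22R cells (Homo sapiens) for antiproliferative activity, read by CCK-8 assay, with a stated time of 6 days (a higher number here means a weaker inhibitor, a lower number a stronger inhibitor), compound 1 (`CCN(c1ccc(C#N)c(Cl)c1)c1cc(-c2cccs2)ccc1C`) gives 22000 nM and compound 2 (`CCN(c1ccc(C#N)c(Cl)c1)c1cc(-c2c[nH]nc2C)ccc1C`) gives 5380 nM as the lower of the two numbers so far. For the measured compounds named here, the single measured step is a 4.1-fold lower number from compound 1 to compound 2 (0.61 log units; beyond the scatter) and it lies beyond the scatter. Compound 3 (`CCN(c1ccc(C#N)c(Cl)c1)c1cc(-n2cccn2)ccc1C`) departs from compound 2 by 1H-pyrazol-1-yl in place of 3-methyl-1H-pyrazol-4-yl on an aromatic carbon in one place, with 1H-pyrazol-1-yl in place of 3-methyl-1H-pyrazol-4-yl on an aromatic carbon. Going by the values given here, only that one measured step bears on this change, and it is an exchange of a different pair of groups, so the guidance is thin. Compound 2 holds the lower number at 5380 nM so a modest move towards a higher number is expected in this assay and no larger than that measured step. The estimated step is a 2.2-fold higher number from compound 2 to compound 3 (0.35 log units; beyond the scatter) for now. Compound 3 is estimated at 12000 nM (expected range 4000 nM to 35000 nM).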

Compound 3, half-maximal inhibitory concentration: > 30000 nM
Compound 3 gave a limit, no number; the forecaster's own chance of this, stated with the estimate: 10%; at least 2.5-fold (0.39 log units) between middle value and limit.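

In this assay, compound 3 carries a limit of the assay and not a number: the limit of > 30000 nM in this assay, at which 1 of the 3 values shown sits.

Even so, this position, on an aromatic carbon para to a methyl group, does not treat the two five-membered aromatic rings alike: the exchange of 3-methyl-1H-pyrazol-4-yl for 1H-pyrazol-1-yl gives an at least 5.5-fold higher number from compound 2 to compound 3 (0.74 log units; beyond the scatter). The other new step, an at least 1.3-fold higher number from compound 1 to compound 3 (0.13 log units; that floor lies within the scatter), leaves 1H-pyrazol-1-yl and thiophen-2-yl unordered.

The exchange removes the methyl group and the hydrogen-bond donor and also moves the ring's point of attachment from carbon to nitrogen, and the compounds shown do not separate these changes. Also open, from the compounds shown here alone, is how an unsubstituted 1H-pyrazol-4-yl, or a non-ring group such as an amine or a carboxylic acid, would read at this position.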